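The compounds below may be only part of what the source reports. "The series", "measured", "known", "first", "only" and "open" are said of these compounds alone.

Of the compounds shown here, three that share one core have been measured in a physicochemical assay for lipophilicity; a lower number here means a more polar compound, a higher number a more lipophilic compound. Compound 1 `CCCCOC(=O)/C=C(C)/C=C/CC(C)CCCC(C)(C)OC` gives 6.62, compound 2 `C#CCCOC(=O)/C=C(C)/C=C/CC(C)CCCC(C)(C)OC` gives 5.2, and compound 3 `CCOC(=O)/C=C(C)/C=C/CC(C)CCCC(C)(C)Cl` gives 6.44. Compound 3 therefore stands second highest of the three: its nearest neighbour is compound 1, whose number cannot be told apart from it within the scatter, while compound 2 lies well below it, beyond the scatter. Among the measured compounds shown here, the only measured step that alters a single place is a number 1.42 log units lower from compound 1 to compound 2 (beyond the scatter), a large drop.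

Compound 4 `CCOC(=O)/C=C(C)/C=C/CC(C)CCC1OC1(C)C` has not yet been measured in this assay. It differs from compound 3 in one place: 3,3-dimethyloxiran-2-yl in place of 2-chloro-2-methylpropyl on a saturated chain carbon, four bonds along the chain from a double-bonded chain carbon. For the measured compounds named here, no measured pair shows this kind of change, a chlorine leaving and a ring oxygen counted as a hydrogen-bond acceptor entering, so the one step on record, from an ethyl to an ethynyl group, bears on it only loosely, as a sign that a change of comparable size at one place can move this read-out well beyond the scatter. With an acceptor entering where none was, a lower number is expected for compound 4, and the expected step is a number 1.14 log units lower from compound 3 to compound 4 (beyond the scatter). Compound 4 is estimated at 5.3, within a range from 4.6 to 6.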

Compound 4, partition coefficient: 4.76
Estimate against measurement, compound 4: 0.54 log units above; the measured number falls inside the stated range.
By their numbers in this assay, from the lowest: compound 4; then compound 2; then compounds 3 and 1 (each within the scatter of the next).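

In this assay, putting 3,3-dimethyloxiran-2-yl in place of 2-chloro-2-methylpropyl gives a number 1.68 log units lower from compound 3 to compound 4 (beyond the scatter), so a single change on a saturated chain carbon, four bonds along the chain from a double-bonded chain carbon, can move this number well beyond the scatter. Among the compounds shown here, the only earlier step lay at a different place, two bonds along the chain from an oxygen next to a carbonyl group, which makes this the first sign that a second place on the shared core also responds strongly. The two groups have the same count of heavy atoms but differ in a chlorine against a ring oxygen, in a three-membered ring, and in a hydrogen-bond acceptor, and no supporting measurement shows which of these differences accounts for the step.

The compounds shown leave open whether the loss of the chlorine, the arrival of the oxygen or the closing of the ring carries the change, as this one step alters all three together. A plain 2-methylpropyl group, or a hydroxyl or an amine at the same place, would be needed to tell these apart.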